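A carboxy group gives way to hydroxy

This account rests on a few compounds, and the source may have more. Where it says the series, first, only, none or still open, it means among the compounds named here.

Compound 1 `C=Cn1c2ccc([N+](=O)[O-])cc2c(=O)n1Cc1ccccc1`: 160000 nM
Compound 2 `O=C(O)CCn1c2ccc([N+](=O)[O-])cc2c(=O)n1Cc1ccccc1`: > 256000 nM (a limit)

In an ADME assay on L929 cells (Mus musculus) for cytotoxicity, read by resazurin assay, with a stated time of 48 h (on this read-out lower numbers stand for higher toxicity in this test and higher numbers for lower toxicity in this test), the two measured compounds share one core and differ only in the group on an aromatic nitrogen. Compound 2 gives > 256000 nM, which is a limit of the assay and not a number. Its exact place on the scale is therefore unknown.

Compound 3 `O=c1c2cc([N+](=O)[O-])ccc2n(CCO)n1Cc1ccccc1` differs from compound 2 by one change, (hydroxy in place of carboxy on a saturated chain carbon, two bonds along the chain from an aromatic nitrogen), so 2-hydroxyethyl stands in place of 2-carboxyethyl. Within the data shown here, no measured step covers this exchange directly. The closest is an at least 1.6-fold higher number from compound 1 to compound 2 (0.20 log units; that floor lies within the scatter), which alters the same group on the aromatic nitrogen and is known only by its floor.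

With so little evidence, no step beyond the scatter can be firmly expected in this assay, although a somewhat lower number is thought possible. Among the measured compounds shown here, the expectation rests on compound 1 at 160000 nM as the only exact value available. The estimated change is an at least 1.3-fold lower number from compound 2 to compound 3 (0.12 log units; that floor lies within the scatter). For compound 3, the expected value is 190000 nM, with an estimated range of 90000 nM to 350000 nM.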

Compound 3, concentration lethal to 50% of the cells: > 256000 nM
Compound 3: only a limit was reported; the forecaster's own chance of this, stated with the estimate: 35%; at least 1.3-fold (0.12 log units) between middle value and limit.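

In this assay, the reading stays at the limit when hydroxy replaces carboxy on the chain: compound 3 gives > 256000 nM, which is a limit and not a number, so a carboxy group is not needed on this chain for a compound to reach it. The step between compound 2 and compound 3 cannot be read, because both stop at the same limit: the limit of > 256000 nM in this assay, at which 2 of the 3 values shown sit.

The only readable comparison for the new compound starts from the vinyl compound, the one exact value here, and shows an at least 1.6-fold higher number from compound 1 to compound 3 (0.20 log units; that floor lies within the scatter), a floor that matches an at least 1.6-fold higher number from compound 1 to compound 2 (0.20 log units; that floor lies within the scatter), so neither 2-hydroxyethyl nor 2-carboxyethyl is shown to go beyond the scatter from vinyl.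

As far as these compounds go, how far the true values of compound 2 and compound 3 lie past the limit remains open, and so does any order between them. Also open, from the compounds shown here alone, is whether an amine or a longer chain on this aromatic nitrogen would stay at the limit or give a number that can be read.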